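A few compounds are considered here, and "the series" means these few. Any claim that something is new, unique, unknown or untested is made for them only; others in the source may bear on it.

Measured in a functional assay on the whole organism for antagonist activity, with Rattus norvegicus as the target; a higher number here means that more compound is needed for the effect, a lower number that less compound is needed:
Compound 1 `CN(C)C1CCN(C(=O)CCCOc2cc(C(=O)N3CCCCc4sccc43)ccc2NC(=O)c2ccccc2-c2ccccc2)CC1`: 0.005 mg/kg
Compound 2 `O=C(Nc1ccc(C(=O)N2CCCCc3sccc32)cc1O)c1ccccc1-c1ccccc1`: 0.04 mg/kg

Of these two, compound 2 stands at the higher number, 0.04 mg/kg, and so needs more compound than compound 1, a gap beyond the scatter. Compound 3 `CN1CCCN(CCCOc2cc(C(=O)N3CCCCc4sccc43)ccc2NC(=O)c2ccccc2-c2ccccc2)CC1` differs from compound 2 by 3-(4-methyl-1,4-diazepan-1-yl)propyl in place of hydrogen on an oxygen on an aromatic ring. Compound 1 also bears a chain on that oxygen and gives 0.005 mg/kg. A lower number, beyond the scatter, is therefore expected, an estimated 4.0-fold lower number from compound 2 to compound 3 (0.60 log units; beyond the scatter). Compound 3 is expected at 0.01 mg/kg, within an estimated range of 0.003 mg/kg to 0.04 mg/kg.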

Compound 3, dose for 50% inhibition: 0.03 mg/kg
For compound 3 the middle estimate is 3.0-fold (0.48 log units) below the measured one, within the range that was stated.
By their numbers in this assay, from the lowest: compound 1; then compounds 3 and 2 (each within the scatter of the next).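

In this assay, placing 3-(4-methyl-1,4-diazepan-1-yl)propyl on the oxygen on an aromatic ring gives a 1.3-fold lower number from compound 2 to compound 3 (0.12 log units; within the scatter) and so leaves compound 3 level with compound 2, showing that a chain here does not by itself bring the gain seen with compound 1. The end of the chain matters, since replacing (4-(dimethylamino)piperidin-1-yl)carbonyl with 4-methyl-1,4-diazepan-1-yl gives a 6.0-fold higher number from compound 1 to compound 3 (0.78 log units; beyond the scatter) on this chain. Nothing available explains this difference.

On these data alone, it remains open whether the carbonyl or the amine of compound 1 carries the difference. As far as these compounds go, how a piperazine, a carboxylic acid or a shorter chain would read at this oxygen also remains open.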